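Carbamate chain variation on the selenocyanate series

The source may hold more compounds than are shown below. What is called first, only, known or untested is meant among the compounds shown, and "the series" means these compounds.

Three compounds of this set have numbers in a functional assay on HT-29 cells (Homo sapiens) for cytotoxicity, read by MTT assay, with a stated time of 72 h; a higher number here means a weaker inhibitor of growth, a lower number a stronger inhibitor of growth. Compound 1 `N#C[Se]c1ccc(NC(=O)OCc2ccc([N+](=O)[O-])cc2)cc1` gives 47100 nM. Compound 2 `CC(C)COC(=O)Nc1ccc([Se][Se]c2ccc(NC(=O)OCC(C)C)cc2)cc1` gives 48600 nM. Compound 3 `N#C[Se]c1ccc(NC(=O)OCc2ccccc2)cc1` gives 41200 nM. The three numbers lie within the usual scatter of one another, so compound 3 cannot be set apart from compound 1 or compound 2 on these data; all three sit together at the same level in this assay.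

Going by the values given here, only one step between measured compounds differs in a single place: a 1.1-fold lower number from compound 1 to compound 3 (0.06 log units; within the scatter). That step concerns the aromatic carbon of the benzyl group and does not touch the saturated chain carbon bound to the oxygen next to the carbonyl group, so it bears on the present change only indirectly, by showing that the carbamate part tolerates alteration without a shift beyond the scatter.

Compound 4 `CCCCCCOC(=O)Nc1ccc([Se]C#N)cc1` differs from compound 3 by pentyl in place of phenyl on a saturated chain carbon bound to an oxygen next to a carbonyl group. Compound 2, which carries an isobutyl group on the carbamate oxygen, gives a number in the same band as compound 3, though it differs in more than one place. Among the compounds with values here, no measured step therefore points to a change beyond the scatter. For compound 4 the expected step is a 1.1-fold higher number from compound 3 to compound 4 (0.04 log units; within the scatter), and compound 4 is estimated at 45000 nM, between 20000 nM and 100000 nM.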

Compound 4, concentration for total growth inhibition: 40300 nM
Compound 4: the middle estimate sits 1.1-fold (0.05 log units) above what was measured; the measured number falls inside the stated range.
By their numbers in this assay, from the lowest: compounds 4, 3, 1 and 2 (each within the scatter of the next).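

In this assay the exchange of the ring for an open chain gives a 1.0-fold lower number from compound 3 to compound 4 (0.01 log units; within the scatter), the first reading taken directly at the saturated chain carbon bound to an oxygen next to a carbonyl group. The earlier step from compound 1 altered only a substituent on the aromatic ring and left the ring in place, whereas here the one six-membered aromatic ring of carbon only leaves altogether and pentyl, with no ring, enters, and the number still stays within the scatter. At this place, then, compound 3 and compound 4 cannot be told apart, so for this pair the aromatic ring is not required to hold the level, and no measured evidence bears on why the two numbers coincide.

All the compounds shown sit at one level, so nothing here marks what would move the number at this place, and a carboxylic acid or an amine on the chain, or a chain much longer than pentyl, remains an open test. The selenocyanate and the diselenide of compound 2 also remain unseparated, since no pair shown differs in that one place alone.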